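A few compounds are considered here, and "the series" means these few. Any claim that something is new, unique, unknown or untested is made for them only; others in the source may bear on it.

Measured in an ADME assay on L1210/0 cells (Mus musculus) for cytotoxicity, with a stated time of 48 h; on this read-out higher numbers stand for weaker inhibition and lower numbers for stronger inhibition:
- Compound 1 `CC1(C)[C@@H](Cn2cnc3c(Cl)nc(N)nc32)CC[C@@]1(C)CO`: 50000 nM
- Compound 2 `Cc1ccc(C(=O)/C=C/c2cc(O)nc(O)n2)cc1`: 182000 nM
- Compound 3 `OC[C@@H]1CC(n2cnc3c(NC4CC4)ncnc32)C[C@@H]1CO`: > 200000 nM

Only the first two of these are true numbers. Compound 3 stands at the limit of > 200000 nM in this assay, at which 1 of the 3 values shown sits. Its entry of > 200000 nM is a limit of the assay and not a number.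

Compound 4 `Nc1ncnc2c1ncn2C1C[C@@H](CO)[C@@H](CO)C1` differs from compound 3 in one place: hydrogen in place of cyclopropyl on a nitrogen on an aromatic ring. Put simply, this is hydrogen in place of cyclopropyl on a nitrogen on an aromatic ring, which turns cyclopropylamino into amino.

Among the measured compounds shown here, no two measured compounds differ in a single place, so the data offer no direct guide to the size of this change. The expectation therefore starts from compound 3 and its > 200000 nM. For the measured compounds named here, compound 1 reads 50000 nM and compound 2 reads 182000 nM, so the numbers measured so far are also high in this assay. Little movement is expected, with at most a slight shift toward stronger inhibition, and compound 4 may well return only a limit too. The expected step of an at least 1.1-fold lower number from compound 3 to compound 4 (0.04 log units; that floor lies within the scatter) is therefore small. If a number is reported, the estimate for compound 4 is 180000 nM, within an expected range of 60000 nM to 400000 nM.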

Compound 4, half-maximal inhibitory concentration: > 200000 nM
Compound 4: only a limit was reported; the forecaster's own chance of this, stated with the estimate: 60%; middle value at least 1.1-fold (0.04 log units) from the limit.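

In this assay, compound 3 gives > 200000 nM, which is a limit of the assay and not a number. Compound 4 gives > 200000 nM, also a limit. No step can be read between compound 3 and compound 4, which share one entry: the limit of > 200000 nM in this assay, at which 2 of the 4 values shown sit. Going by these compounds, whether changing cyclopropylamino to amino affects this read-out at all stays open.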